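The compounds below may be only part of what the source reports. "The series", "measured", "known", "first", "only" and "open" are said of these compounds alone.

Measured in a functional assay on THP-1 cells (Homo sapiens) for inhibition; a higher number here means a weaker inhibitor of growth, a lower number a stronger inhibitor of growth:

- compound 1 `Cc1noc(C)c1-c1ccc2c(c1)c(Cc1ccccc1)cn2CCCCCC(=O)NO` gives 15500 nM in growth inhibition
- compound 2 `Cc1noc(C)c1-c1ccc2c(c1)c(Cc1ccc(F)cc1)cn2CCCCCC(=O)NO` gives 15500 nM in growth inhibition
- compound 3 `Cc1noc(C)c1-c1ccc2c(c1)c(CCc1ccc(F)cc1)cn2CCCCCCC(=O)NO` gives 15500 nM in growth inhibition

Compound 1 and compound 3 stand level with compound 2 at 15500 nM in this assay, so the three measured compounds show no separation. The next structure, compound 4 `Cc1ccccc1Cc1cn(CCCCCC(=O)NO)c2ccc(-c3c(C)noc3C)cc12`, departs from compound 2 through (2-methylphenyl in place of 4-fluorophenyl on a saturated chain carbon bound to an aromatic carbon), which in words is 2-methylphenyl in place of 4-fluorophenyl on a saturated chain carbon bound to an aromatic carbon.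

For the measured compounds named here, only one measured step touches that ring. It is no change at the digits printed from compound 1 to compound 2 (within the scatter), with fluoro in place of hydrogen on an aromatic carbon, and it lies within the scatter. Going by the values given here, no measured compound carries the 2-methylphenyl group, so this evidence is indirect. A step beyond the scatter is therefore not expected, and no direction can be favoured.

The estimated change is a 1.0-fold lower number from compound 2 to compound 4 (0.01 log units; within the scatter), which is expected to remain within the scatter. For compound 4 the estimated value is 15000 nM, with an expected range from 7500 nM to 26000 nM in this assay.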

Compound 4, concentration for 50% growth inhibition: 15500 nM
Beside the measured number, compound 4's estimate is 1.0-fold (0.01 log units) below it; low and high end bracket the measured number.
By their numbers in this assay, from the lowest: compounds 1, 2, 3 and 4 (each within the scatter of the next).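

In this assay, 2-methylphenyl in place of 4-fluorophenyl on a saturated chain carbon bound to an aromatic carbon gives no change at the digits printed from compound 2 to compound 4 (within the scatter), and adding only a methyl group to that ring gives no change at the digits printed from compound 1 to compound 4 (within the scatter). For the compounds shown here, earlier, the only measured change on this ring was a fluoro group; these steps show that a methyl group, carried at the 2-position rather than the 4-position named for the fluoro group, also leaves the read-out within the scatter. Nothing available accounts for this result.

The compounds shown leave open whether any group on this ring can move the value away from the level shared by all four compounds. An amine or a carboxylic acid on that ring would test this, as would a longer chain in place of the methyl group.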